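The source may report more compounds than this note shows. Statements on the series, on what has been measured and on what is new or still open speak of the compounds shown alone.

Measured so far:
compound 1 `c1ccc(N2CCN(CCCCCOc3ccc4c(c3)CCC4)CC2)cc1`: 25%
compound 2 `Fc1ccc(N2CCN(CCCCCOc3ccc4c(c3)CCC4)CC2)cc1`: 71%

In a functional assay on the whole organism for inhibition, with Mus musculus as the target, at a dose of 25 mg/kg by the oral route (on this read-out lower numbers stand for less inhibition and higher numbers for more inhibition at the one dose given (going by the name of the read-out)), compound 1 gives 25%, and compound 2 gives 71%. For the measured compounds named here, the single measured step, a number 46 percentage points higher from compound 1 to compound 2 (beyond the scatter), comes from fluoro in place of hydrogen on an aromatic carbon. Compound 2 therefore stands highest of the two numbers, with compound 1 as its nearest neighbour at a distance beyond the scatter.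

Compound 3 `FC(F)(F)c1cccc(N2CCN(CCCCCOc3ccc4c(c3)CCC4)CC2)c1` is not yet measured. It differs from compound 2 by 3-(trifluoromethyl)phenyl in place of 4-fluorophenyl on an amine nitrogen in a ring. Going by the values given here, no measured step shows this exchange: the only step in hand, a number 46 percentage points higher from compound 1 to compound 2 (beyond the scatter), concerns a single fluorine and a different group, so it bears on the new change only loosely, showing that alteration of this aryl group can move the read-out by a large amount. Since compound 2 gives 71% and the new group keeps fluorine on the aryl ring, compound 3 is expected to remain in the same region, with a modest downward step, a number 11 percentage points lower from compound 2 to compound 3 (beyond the scatter), allowed for by the wide range. Compound 3 is estimated at 60%, between 30% and 85%.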

Compound 3, a percentage reported as inhibition, in the whole organism at one dose (the size of the read-out at that dose, not a potency): 66%
Compound 3: the middle estimate sits 6 percentage points below what was measured; low and high end bracket the measured number.
By their numbers in this assay, from the lowest: compound 1; then compounds 3 and 2 (each within the scatter of the next).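

In this assay, replacing 4-fluorophenyl with 3-(trifluoromethyl)phenyl on the amine nitrogen in a ring gives a number 5 percentage points lower from compound 2 to compound 3 (within the scatter), so the read-out does not separate these two aryl groups, even though the entering group has more heavy atoms and carries a different fluorinated substituent. Set against the unsubstituted phenyl of compound 1, the trifluoromethyl group gives a number 41 percentage points higher from compound 1 to compound 3 (beyond the scatter), a large step in the same direction as a number 46 percentage points higher from compound 1 to compound 2 (beyond the scatter), so among these three compounds the rise is not tied to a single fluorine on the aryl ring and neither substituted compound goes against it. No measurement bears on why either substituent raises the read-out.

As far as these compounds go, compound 2 and compound 3 differ in both the substituent and its place on the aryl ring, so whether that place matters on its own remains open. From the compounds shown here alone, it also remains open whether a substituent without fluorine, such as a methoxy group or a nitrile, would give a similar rise over compound 1, and whether a shorter chain on the other ring nitrogen would keep it.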